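The source may report more compounds than this note shows. Statements on the series, on what has been measured and on what is new or still open speak of the compounds shown alone.

Measured in a functional assay on PLC-PRF-5 cells (Homo sapiens) for inhibition, read by MTT assay, with a stated time of 72 h; a higher number here means a weaker inhibitor, a lower number a stronger inhibitor:
- compound 1 `Nc1nc2cc(-c3nn(CCCCC(=O)NO)c4ncnc(N)c34)ccc2o1`: 29600 nM
- compound 2 `Nc1nc2cc(-c3nn(CCCCCC(=O)NO)c4ncnc(N)c34)ccc2o1`: > 50000 nM (a limit of the assay)
- compound 3 `CNC(=O)CCCCCCCn1nc(-c2ccc3oc(N)nc3c2)c2c(N)ncnc21`: 30500 nM

Compound 3 has one of the two numerical values in the series, and it lies within the scatter of compound 1: a 1.0-fold higher number from compound 1 to compound 3 (0.01 log units; within the scatter). The next candidate is compound 4 `Nc1nc2cc(-c3nn(CCCCCCC(=O)NO)c4ncnc(N)c34)ccc2o1`, which differs from compound 3 as follows: hydroxycarbamoyl in place of (methylcarbamoyl)methyl on a saturated chain carbon, six bonds along the chain from an aromatic nitrogen. In words, hydroxycarbamoyl stands in place of (methylcarbamoyl)methyl on a saturated chain carbon, six bonds along the chain from an aromatic nitrogen.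

The closest precedents are the step above and an at least 1.6-fold lower number from compound 2 to compound 3 (0.21 log units; that floor lies within the scatter), both of which exchange a hydroxycarbamoyl end for a methylcarbamoyl end. The remaining step, an at least 1.6-fold higher number from compound 1 to compound 2 (0.22 log units; that floor lies within the scatter), compares the two hydroxycarbamoyl compounds. None of these shows a change beyond the scatter, although two of them give only a floor. No step beyond the scatter is therefore expected in this assay. The expected step is a 1.2-fold lower number from compound 3 to compound 4 (0.09 log units; within the scatter). Compound 4 is estimated at 25000 nM, with an expected range of 6000 nM to 50000 nM.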

Compound 4, half-maximal inhibitory concentration: > 50000 nM
Compound 4 gave a limit, no number; the forecaster's own chance of this, stated with the estimate: 25%; at least 2.0-fold (0.30 log units) between middle value and limit.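

Compound 4 joins compound 2 at a limit of this assay, so neither hydroxycarbamoyl chain longer than that of compound 1 gives a number: the limit of > 50000 nM in this assay, at which 2 of the 4 values shown sit.

At this place, six bonds along the chain from an aromatic nitrogen, hydroxycarbamoyl in place of (methylcarbamoyl)methyl gives an at least 1.6-fold higher number from compound 3 to compound 4 (0.21 log units; that floor lies within the scatter), and 2-(hydroxycarbamoyl)ethyl in place of hydroxycarbamoyl gives an at least 1.6-fold higher number from compound 1 to compound 4 (0.22 log units; that floor lies within the scatter). Both are floors rather than sizes, so no step beyond the scatter is shown, and the step between compound 2 and compound 4 cannot be read.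

On these data alone, whether the hydroxycarbamoyl end and the methylcarbamoyl end differ beyond the scatter at any chain length remains open. Also open, as far as these compounds go, is how a carboxylic acid or a primary amine at the chain end would read in this assay.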